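From azetidin-1-yl to piperidin-1-yl on a sulfonyl sulfur

The compounds below may be only part of what the source reports. "The series", "measured", "known", "first", "only" and "open" are said of these compounds alone.

In a toxicity assay on Vero cells (Chlorocebus sabaeus) for cytotoxicity, read by MTT assay (on this read-out higher numbers stand for weaker inhibition and lower numbers for stronger inhibition), compound 2 `CCOC(=O)NC(=O)c1ccsc1NC(=O)c1ccc(S(=O)(=O)N2CCC2)cc1` reads > 64 ug/mL and that is a limit of the assay, not a number. Compound 3 `CCOC(=O)NC(=O)c1ccsc1NC(=O)c1ccc(S(=O)(=O)N2CCCCC2)cc1` has piperidin-1-yl in place of azetidin-1-yl on a sulfonyl sulfur and is otherwise the same as compound 2. Compound 1 `CCCOC(=O)NC(=O)c1ccsc1NC(=O)c1ccc(S(=O)(=O)N2CCCCC2)cc1` also carries piperidin-1-yl on its sulfonyl sulfur and gives 56.6 ug/mL as a true measured number. Within the data shown here, with compound 1 at 56.6 ug/mL as the only guide, the expected step of an at least 1.1-fold lower number from compound 2 to compound 3 (0.04 log units; that floor lies within the scatter) is none beyond the scatter of this assay in either direction. Compound 3 is expected at 58 ug/mL with 30 ug/mL to 100 ug/mL as its range.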

Compound 3, half-maximal inhibitory concentration: 18.6 ug/mL
For compound 3 the middle estimate is 3.1-fold (0.49 log units) above the measured one, outside the stated range (below it).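

In this assay the sulfonyl sulfur proves to be a place that matters: piperidin-1-yl in place of azetidin-1-yl gives an at least 3.4-fold lower number from compound 2 to compound 3 (0.53 log units; beyond the scatter) and so moves toward stronger inhibition. Compound 2 stands at a limit of the assay and not at a number: the limit of > 64 ug/mL in this assay, at which 1 of the 3 values shown sits. Hydrogen in place of methyl on a saturated chain carbon, with piperidin-1-yl kept, gives a 3.0-fold lower number from compound 1 to compound 3 (0.48 log units; beyond the scatter) and so the chain counts as well. From the compounds shown here alone, how a pyrrolidin-1-yl or morpholin-4-yl ring on the sulfonyl sulfur would read stays open. So does the reading of a butyl chain in place of the chains shown.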